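Dimethylphenyl amide in a flavonol series: an expected gain

The compounds below may be only part of what the source reports. "The series", "measured", "known", "first", "only" and "open" are said of these compounds alone.

Compound 1: `COc1ccc(C(=O)Nc2cccc(-c3oc4cc(-c5ccc(F)cc5)ccc4c(=O)c3O)c2)cc1`, 16500 nM
Compound 2: `Cc1ccc(C(=O)Nc2cccc(-c3oc4cc(-c5ccc(F)cc5)ccc4c(=O)c3O)c2)cc1`, 4350 nM
Compound 3: `O=C(Nc1cccc(-c2oc3cc(-c4ccc(F)cc4)ccc3c(=O)c2O)c1)c1ccc(C(F)(F)F)cc1`, 29400 nM

The three measured compounds share one core and differ only in the substituent on the phenyl ring of the amide. In a functional assay on MDA-MB-231 cells (Homo sapiens) for antiproliferative activity, read by CCK-8 assay, with a stated time of 72 h (a higher number here means a weaker inhibitor, a lower number a stronger inhibitor), compound 3 gives the highest number of the three. Its nearest neighbour is compound 1, with a step of a 1.8-fold higher number from compound 1 to compound 3 (0.25 log units; within the scatter); its furthest is compound 2, with a step of a 6.8-fold higher number from compound 2 to compound 3 (0.83 log units; beyond the scatter). Between compounds 1 and 2 the step is a 3.8-fold lower number from compound 1 to compound 2 (0.58 log units; beyond the scatter).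

Compound 4, `Cc1cc(C)cc(C(=O)Nc2cccc(-c3oc4cc(-c5ccc(F)cc5)ccc4c(=O)c3O)c2)c1`, has not been measured. Compared with compound 3 it carries 3,5-dimethylphenyl in place of 4-(trifluoromethyl)phenyl on a carbonyl carbon.

Among the measured compounds shown here, the step that bears most on this change is the one from compound 2 to compound 3, which was modest and beyond the scatter, since compound 4 returns to methyl substitution, now with two methyl groups on the ring. The step from compound 1 to compound 3 lay within the scatter and adds little. On this basis compound 4 is expected to give a lower number than compound 3 in this assay, a step of roughly the size seen between compounds 2 and 3, estimated as a 5.9-fold lower number from compound 3 to compound 4 (0.77 log units; beyond the scatter). The estimate for compound 4 is 5000 nM, with a range from 2000 nM to 13000 nM.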

Compound 4, half-maximal inhibitory concentration: 11900 nM
Compound 4: the middle estimate sits 2.4-fold (0.38 log units) below what was measured, and the stated range covers the measured number.
By their numbers in this assay, from the lowest: compound 2; then compounds 4, 1 and 3 (each within the scatter of the next, the first and the last beyond it).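

In this assay, putting 3,5-dimethylphenyl in place of 4-(trifluoromethyl)phenyl on the carbonyl carbon gives a 2.5-fold lower number from compound 3 to compound 4 (0.39 log units; beyond the scatter), so the position still responds to this exchange. The new group does not reach the level of 4-methylphenyl, however, as the step is a 2.7-fold higher number from compound 2 to compound 4 (0.44 log units; beyond the scatter), which shows that methyl substitution on this ring does not in itself bring the low number of compound 2, and that compound 2 stands alone, beyond the scatter from each of the other three. Against the 4-methoxyphenyl amide the step is a 1.4-fold lower number from compound 1 to compound 4 (0.14 log units; within the scatter), so compound 4 cannot be told apart from compound 1, and nothing at hand gives a measured reason for these differences.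

As far as these compounds go, it remains open how this position would respond to a ring carrying a chlorine atom, a dimethylamino group or a carboxylic acid, or to an ethyl group in place of methyl. It also remains open whether the order among these amides would hold if another part of the shared core were changed.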